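The compounds below may be only part of what the source reports. "The series", "measured", "known", "first", "only" and "open" are said of these compounds alone.

In a functional assay on QGY-7703 cells (Homo sapiens) for cytotoxicity, read by MTT assay, with a stated time of 24 h (a higher number here means a weaker inhibitor, a lower number a stronger inhibitor), three compounds built on related cores have been measured. Compound 1 (`CN1C/C(=C\c2cccnc2)C(=O)/C(=C/c2ccc(F)cc2Br)C1`) gives 2610 nM, and compound 2 (`COc1cc(/C=C2\CN(C)C/C(=C\c3ccncc3)C2=O)cc(OC)c1OC`) gives 5900 nM. Compound 3 (`O=C1/C(=C/c2cccnc2)CNC/C1=C\c1ccccc1F`) gives 8890 nM. Among the measured compounds shown here, that value lies within the scatter of the one for compound 2, and it marks a weaker inhibitor than compound 1, by a gap beyond the scatter.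

Compound 4 (`Cc1ccc(S(=O)(=O)N2C/C(=C\c3cccnc3)C(=O)/C(=C/c3ccccc3F)C2)cc1`) departs from compound 3 at a single place, with (4-methylphenyl)sulfonyl in place of hydrogen on an amine nitrogen in a ring. For the measured compounds named here, no measured pair isolates a change at this nitrogen, so the expectation is loose and rests on the span of the data, which runs down to compound 1 at 2610 nM. A moderate move toward stronger inhibition is expected, and a result within the scatter of compound 3 would not be surprising. The estimated change is a 2.5-fold lower number from compound 3 to compound 4 (0.40 log units; beyond the scatter). Compound 4 is expected at about 3500 nM, with an estimated range from 1000 nM to 11000 nM.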

Compound 4, half-maximal inhibitory concentration: 9700 nM
For compound 4 the middle estimate is 2.8-fold (0.44 log units) below the measured one; the range from low to high includes it.
By their numbers in this assay, from the lowest: compound 1; then compounds 2, 3 and 4 (each within the scatter of the next).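

In this assay, among the compounds shown here, placing (4-methylphenyl)sulfonyl on the amine nitrogen in the ring in place of hydrogen gives a 1.1-fold higher number from compound 3 to compound 4 (0.04 log units; within the scatter), the first reading of a single change in this set. At this nitrogen, then, adding 10 heavy atoms, including an aromatic ring of carbon only, does not move the number beyond the scatter. No measurement shown accounts for this result.

The compounds shown leave open whether an acetyl or a benzyl group on this nitrogen would also stay within the scatter of compound 3, and whether a sulfonyl group carrying a plain methyl would match the (4-methylphenyl)sulfonyl group. On these data alone, it also remains open whether the same exchange would read alike when the other groups on the shared core differ.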